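Swapping the Amide Substituent: What to Expect for Compound 4

This account rests on a few compounds, and the source may have more. Where it says the series, first, only, none or still open, it means among the compounds named here.

Compound 1 `CCCN(C(=O)CN(C)C(=O)c1ccc(S(C)(=O)=O)c([N+](=O)[O-])c1)c1ccccc1` gives in an assay on isolated protein for inhibition of vitamin D3 receptor (Homo sapiens), read by fluorescence polarization (on this read-out lower numbers stand for stronger inhibition and higher numbers for weaker inhibition), only the assay limit > 60000 nM.
Compound 2 `CN(Cc1cccc(F)c1)C(=O)CN(C)C(=O)c1ccc(S(C)(=O)=O)c([N+](=O)[O-])c1` gives in this assay only the assay limit > 60000 nM.
Compound 3 `CS(=O)(=O)c1ccc(C(=O)NCC(=O)N2CCCCC2)cc1[N+](=O)[O-]` gives in this assay only the assay limit > 60000 nM.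

Compound 2 therefore stands at the edge of what this assay can report: its value is a limit, not a number, and the same holds for compound 1 and compound 3. Among the compounds with values here, the one measured step between neighbours, a step that the two limits leave unreadable from compound 1 to compound 2, cannot be read, since both ends are limits. Within the data shown here, compound 3 shares the core but has no single-point step to the others; it shows only the same limit.

Compound 4 `CC1CCN(C(=O)CN(C)C(=O)c2ccc(S(C)(=O)=O)c([N+](=O)[O-])c2)CC1` differs from compound 2 by 4-methylpiperidin-1-yl in place of (3-fluorobenzyl)(methyl)amino on a carbonyl carbon. Among the measured compounds shown here, no measured step bears on this change in a readable way. Because every value shown sits at the limit (the limit of > 60000 nM in this assay, at which 3 of the 3 values shown sit), the expectation is that compound 4 will again give no number in this assay, and no step beyond the scatter can be expected in either direction. The estimated step from compound 2 to compound 4 is a step that the limit leaves unreadable from compound 2 to compound 4, an expectation rather than a measurement. For compound 4 the estimate in this assay is 80000 nM, with an expected range from 30000 nM to 300000 nM, most likely reported as a limit.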

Compound 4, half-maximal inhibitory concentration: > 60000 nM
Compound 4 was reported as a limit (the forecaster's own chance of this, stated with the estimate: 85%); the middle value is on the limit's open side.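

In this assay compound 4 gives > 60000 nM as a limit, not a number, so the steps to compound 4 from compound 1 and from compound 2 cannot be read. The compounds shown leave open whether any group on this carbonyl carbon can give a readable value, because all of them stop at the same point: the limit of > 60000 nM in this assay, at which 4 of the 4 values shown sit.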